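Removing the para chloro from compound 1's benzylamine

The compounds below may be only part of what the source reports. "The series", "measured", "known", "first", "only" and "open" are said of these compounds alone.

Measured compounds:
Compound 1, `O=S(=O)(NCCCNCc1ccc(Cl)cc1)c1cc(C(F)(F)F)cc(C(F)(F)F)c1`: 2800 nM
Compound 2, `COc1ccc(CNCCCNS(=O)(=O)c2cc(C(F)(F)F)cc(C(F)(F)F)c2)cc1OC`: 3500 nM
Compound 3, `COc1cccc(CNCCCNS(=O)(=O)c2cc(C(F)(F)F)cc(C(F)(F)F)c2)c1`: 2400 nM

All three share a core and were tested in a functional assay on HPAC cells (Homo sapiens) for inhibition, read by MTT assay, with a stated time of 72 h; a higher number here means a weaker inhibitor of growth, a lower number a stronger inhibitor of growth. Compound 1 gives the second highest of the three numbers, yet the two steps that reach it, a 1.3-fold higher number from compound 1 to compound 2 (0.10 log units; within the scatter) and a 1.2-fold lower number from compound 1 to compound 3 (0.07 log units; within the scatter), both lie within the scatter, so the three compounds cannot be ordered. The change from compound 2 to compound 3 was also small, a 1.5-fold lower number from compound 2 to compound 3 (0.16 log units; within the scatter).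

Compound 4, `O=S(=O)(NCCCNCc1ccccc1)c1cc(C(F)(F)F)cc(C(F)(F)F)c1`, has not yet been measured. It differs from compound 1 as follows: hydrogen in place of chloro on an aromatic carbon. Among the compounds with values here, no measured step removes a chloro, so none bears directly on this change; what the data do show is that exchanging one aryl group for another, or removing a methoxy, left this assay unchanged within the scatter in every case. The step from compound 1 to compound 4 is therefore expected to be no larger than the scatter, a 1.1-fold higher number from compound 1 to compound 4 (0.03 log units; within the scatter). Compound 4 is estimated at 3000 nM, within 1500 nM to 6500 nM.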

Compound 4, concentration for 50% growth inhibition: 3200 nM
The estimate for compound 4 lay 1.1-fold (0.03 log units) below the measured number, within the range that was stated.
By their numbers in this assay, from the lowest: compounds 3, 1, 4 and 2 (each within the scatter of the next).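

In this assay, removing the chloro para to a large group gives a 1.1-fold higher number from compound 1 to compound 4 (0.06 log units; within the scatter), which shows that this position tolerates the loss of its substituent, leaving a plain phenyl, without a change beyond the scatter. The plain phenyl also cannot be separated from either methoxy-bearing ring, with a 1.3-fold higher number from compound 3 to compound 4 (0.12 log units; within the scatter) and a 1.1-fold lower number from compound 2 to compound 4 (0.04 log units; within the scatter), so across these four compounds neither chloro nor methoxy distinguishes itself from hydrogen. Nothing available explains why this ring's substituents leave the number unchanged within the scatter. From the compounds shown here alone, whether that holds for a carboxylic acid or an amine on the same ring remains open. The compounds also leave open how a longer chain in place of the one they share, or a replacement for either trifluoromethyl, would behave on the shared core.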